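Chain substituent variation in a kinase binding series

A few compounds are considered here, and "the series" means these few. Any claim that something is new, unique, unknown or untested is made for them only; others in the source may bear on it.

Measured compounds:
Compound 1, `Cn1ncc(Cl)c1-c1cc(C(=O)N[C@@H]2CN[C@H](CCn3cncn3)C[C@H]2c2ccc(Cl)c(Cl)c2)oc1Cl`, gives 4.47 nM in an assay for inhibition of RAC-alpha serine/threonine-protein kinase (Homo sapiens), read by HTRF, with a stated time of 1 h; a higher number here means a weaker inhibitor, a lower number a stronger inhibitor.
Compound 2, `CNC(=O)C[C@@H]1C[C@@H](c2ccc(F)c(F)c2)[C@H](NC(=O)c2cc(-c3c(Cl)cnn3C)c(Cl)o2)CN1`, gives 1.37 nM in this assay.
Compound 3, `Cn1ncc(Cl)c1-c1cc(C(=O)N[C@@H]2CN[C@H](CC(=O)NC3CCC3)C[C@H]2c2ccc(Cl)c(Cl)c2)oc1Cl`, gives 7.98 nM in this assay.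

Compound 3 stands highest of the three numbers in this assay. Its nearest neighbour is compound 1, the step of a 1.8-fold higher number from compound 1 to compound 3 (0.25 log units; within the scatter) lying within the scatter. Compound 2 shows a lower number, and the gap between compound 2 and compound 3 lies beyond the scatter.

Compound 4, `Cn1ncc(Cl)c1-c1cc(C(=O)N[C@@H]2CN[C@H](CCCO)C[C@H]2c2ccc(Cl)c(Cl)c2)oc1Cl`, is not yet measured. It differs from compound 3 as follows: 2-hydroxyethyl in place of cyclobutylcarbamoyl on a saturated chain carbon bound to a saturated ring carbon.

Among the measured compounds shown here, the one measured step that bears on this is a 1.8-fold higher number from compound 1 to compound 3 (0.25 log units; within the scatter), where the group on the saturated chain carbon bound to a saturated ring carbon was exchanged and the number barely moved. For the measured compounds named here, the hydroxyethyl group entering is small, and no measured compound carries it, so the step is expected to stay within the scatter, with the number for compound 4 estimated to be about a 1.3-fold lower number from compound 3 to compound 4 (0.12 log units; within the scatter) against compound 3. Compound 4 is therefore expected to give around 6 nM in this assay, with a plausible range from 2 nM to 18 nM.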

Compound 4, half-maximal inhibitory concentration: 2.56 nM
Compound 4: the middle estimate sits 2.3-fold (0.37 log units) above what was measured; measured number inside the range.
By their numbers in this assay, from the lowest: compounds 2, 4, 1 and 3 (each within the scatter of the next, the first and the last beyond it).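

Among the compounds shown here, at the saturated chain carbon bound to a saturated ring carbon, this assay now shows a step beyond the scatter: a 3.1-fold lower number from compound 3 to compound 4 (0.49 log units; beyond the scatter) with 2-hydroxyethyl in place of cyclobutylcarbamoyl, whereas the one earlier step here stayed within it. The exchange of hydroxymethyl for 1H-1,2,4-triazol-1-yl on a saturated chain carbon, two bonds along the chain from a saturated ring carbon, gives a 1.7-fold lower number from compound 1 to compound 4 (0.24 log units; within the scatter) and stays within the scatter, so the triazole and hydroxyl chains cannot be told apart here. No measurement available explains the step from cyclobutylcarbamoyl to 2-hydroxyethyl.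

From the compounds shown here alone, how a primary amine, a carboxylic acid or a longer chain ending in hydroxyl would behave at this position remains open. A methyl ether of compound 4 would test whether the hydroxyl hydrogen matters at all.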